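The compounds below may be only part of what the source reports. "The series", "measured", "known", "first", "only" and "open" are said of these compounds alone.

Measured so far in a functional assay on CRL2813 cells (Homo sapiens) for cytotoxicity, read by sulforhodamine B assay, with a stated time of 5 days; a lower number here means a stronger inhibitor, a higher number a weaker inhibitor:

Compound 1 `O=C(Nc1cccc(C(=O)O)c1)N[C@H]1CC[C@H](Oc2ccc(F)cc2)CC1` gives > 20000 nM, which is a limit of the assay.
Compound 2 `COC(=O)c1ccc(NC(=O)N[C@H]2CC[C@H](Oc3ccc(F)cc3)CC2)cc1` gives 11600 nM.
Compound 3 `O=C(Nc1cccc([N+](=O)[O-])c1)N[C@H]1CC[C@H](Oc2ccc(F)cc2)CC1` gives 6700 nM.

Compound 3 gives the lower of the two numbers, but compound 2 sits within the usual scatter of it, so the two cannot be ranked. Going by the values given here, the one step measured is an at least 2.9-fold lower number from compound 1 to compound 3 (0.47 log units; beyond the scatter). Compound 1 stands at the limit of > 20000 nM in this assay, at which 1 of the 3 values shown sits, so only a lower bound of that step is known.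

Compound 4 `COc1ccccc1NC(=O)N[C@H]1CC[C@H](Oc2ccc(F)cc2)CC1` has not been measured. It differs from compound 3 thus: 2-methoxyphenyl in place of 3-nitrophenyl on an amide-type nitrogen. The measured step bears on this only loosely: it alters the same aryl group on the amide-type nitrogen, but exchanges carboxy for nitro, whereas here 3-nitrophenyl leaves and 2-methoxyphenyl enters. Compound 2, bearing a methyl ester on its aryl group, gives a number within the scatter of compound 3, so the substituted phenyl groups measured so far give similarly weak numbers. No step beyond the scatter is expected in this assay, with a slight rise more likely than a fall. Compound 4 is expected to give 10000 nM, between 3500 nM and 30000 nM. The estimated step is a 1.5-fold higher number from compound 3 to compound 4 (0.17 log units; within the scatter).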

Compound 4, half-maximal inhibitory concentration: > 20000 nM
Compound 4 was reported as a limit; the forecaster's own chance of this, stated with the estimate: 25%; middle value at least 2.0-fold (0.30 log units) from the limit.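

In this assay compound 4 gives > 20000 nM, which is a limit. Placing 2-methoxyphenyl in place of 3-nitrophenyl on the amide-type nitrogen gives an at least 2.9-fold higher number from compound 3 to compound 4 (0.47 log units; beyond the scatter), so this position does not give similar numbers for every substituted phenyl group, and a carboxy group is not needed to reach the limit. The step between compound 1 and compound 4 cannot be read, and the limit now covers more of the series: the limit of > 20000 nM in this assay, at which 2 of the 4 values shown sit.

From the compounds shown here alone, it remains open whether the loss follows the methoxy group itself or its location on the phenyl ring, and how far beyond the limit compound 4 lies. Also open, going by these compounds, is whether an amine or a nitrile on the phenyl ring would give a number within the range of the assay.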